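Swapping benzyl for cyclopentyl on a sulfonamide nitrogen

This account rests on a few compounds, and the source may have more. Where it says the series, first, only, none or still open, it means among the compounds named here.

Measured compounds:
compound 1, `CN(Cc1ccccc1)S(=O)(=O)c1ccc(NC(=O)NCc2ccncc2)cc1`, 23 nM
compound 2, `O=C(NCc1cn[nH]c1)Nc1ccc(S(=O)(=O)c2ccc(Cl)cc2)cc1`, 23 nM
compound 3, `CCOC(=O)c1ccc(NC(=O)NCc2cnco2)cc1`, 6900 nM

In an assay on isolated protein for activation of Nicotinamide phosphoribosyltransferase (Homo sapiens) (on this read-out lower numbers stand for an effect already at smaller amounts and higher numbers for an effect only at larger amounts of compound), compound 1 gives 23 nM. On the numbers shown, compound 1 and compound 2 are level at the digits printed, and together they stand at the lowest of the three numbers; compound 2 gives 23 nM. Compound 3 is the furthest away, at 6900 nM, a gap well beyond the scatter. Compound 1 and compound 2 share the urea-linked core and differ both in the sulfur-bound group and in the heteroaryl arm, yet their values do not differ, which suggests that the group attached to the sulfonyl sulfur can be varied without a large effect in this assay.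

Compound 4, `CN(C1CCCC1)S(=O)(=O)c1ccc(NC(=O)NCc2ccncc2)cc1`, has not been measured. Its change from compound 1 is cyclopentyl in place of benzyl on a sulfonamide nitrogen. Because compound 1 stands at 23 nM and compound 2 stands level with it at 23 nM despite different groups at that end, the step from compound 1 to compound 4 is expected to be small, if anything a modest rise, so a 1.7-fold higher number from compound 1 to compound 4 (0.24 log units; within the scatter) is the expected step. Compound 4 is therefore estimated at 40 nM, within a range of 10 nM to 160 nM.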

Compound 4, half-maximal effective concentration: 123 nM
For compound 4 the middle estimate is 3.1-fold (0.49 log units) below the measured one; the measured number falls inside the stated range.
By their numbers in this assay, from the lowest: compounds 1 and 2 (each within the scatter of the next); then compound 4; then compound 3.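

In this assay, the group on the sulfonamide nitrogen matters: cyclopentyl in place of benzyl gives a 5.3-fold higher number from compound 1 to compound 4 (0.73 log units; beyond the scatter), a modest step but one beyond the scatter. For the compounds shown here, compounds 1 and 2 differ in more than one place, so this is the first comparison that isolates this position, and it shows that benzyl cannot be exchanged for cyclopentyl here without a measurable loss on this read-out. The change replaces a six-membered aromatic ring with a smaller five-membered non-aromatic one, and nothing available explains the step.

The compounds shown do not separate ring size from aromatic character, which cyclohexyl or phenyl on the same nitrogen could help to do. Also open, going by these compounds, is how a pyridylmethyl group or a longer chain such as phenethyl would fare at this position.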